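The source may hold more compounds than are shown below. What is called first, only, known or untested is meant among the compounds shown, and "the series" means these compounds.

Of the compounds shown here, three that share one core have been measured in an ADME assay on Vero cells (Chlorocebus sabaeus) for antiproliferative activity, read by MTT assay; on this read-out lower numbers stand for stronger inhibition and higher numbers for weaker inhibition. Compound 1 `c1ccc2c(c1)ccn2-c1nc(N2CCNCC2)nc2ccccc12` gives 8.9 ug/mL, compound 2 `c1ccc(N2CCN(c3nc(-n4ccc5ccccc54)c4ccccc4n3)CC2)cc1` gives 50 ug/mL, and compound 3 `CN1CCN(c2nc(-n3ccc4ccccc43)c3ccccc3n2)CC1` gives 22.3 ug/mL, the second highest of the three numbers. The next compound, compound 4 `c1ccc2c(c1)ccn2-c1nc(N2CCCCC2)nc2ccccc12`, carries piperidin-1-yl in place of 4-methylpiperazin-1-yl on an aromatic carbon, between two ring nitrogen atoms: piperidin-1-yl in place of 4-methylpiperazin-1-yl on an aromatic carbon. Among the measured compounds shown here, no measured step makes this exact change. For the measured compounds named here, the steps that bear on it only exchange the group on an amine nitrogen in a ring, and all are modest: a 2.5-fold higher number from compound 1 to compound 3 (0.40 log units; beyond the scatter), a 5.6-fold higher number from compound 1 to compound 2 (0.75 log units; beyond the scatter) and a 2.2-fold lower number from compound 2 to compound 3 (0.35 log units; beyond the scatter). None of them removes that nitrogen, so they suggest a likely size but not a direction. In this assay, no step beyond the scatter is therefore expected, although a modest step either way remains possible. The expected change is a 1.1-fold higher number from compound 3 to compound 4 (0.03 log units; within the scatter). Compound 4 is estimated at 24 ug/mL, with an expected range of 10 ug/mL to 55 ug/mL.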

Compound 4, half-maximal inhibitory concentration: 50 ug/mL
Compound 4: the middle estimate sits 2.1-fold (0.32 log units) below what was measured; the range from low to high includes it.
By their numbers in this assay, from the lowest: compound 1; then compound 3; then compounds 2 and 4 (each within the scatter of the next).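

Unlike the earlier steps, which only exchanged the group on the ring amine nitrogen, this change removes that nitrogen, and in this assay the number rises beyond the scatter (a 2.2-fold higher number from compound 3 to compound 4 (0.35 log units; beyond the scatter)). The step from the unsubstituted piperazin-1-yl is larger and points the same way (a 5.6-fold higher number from compound 1 to compound 4 (0.75 log units; beyond the scatter)), so at this aromatic carbon, between two ring nitrogen atoms, both compounds that keep the second ring nitrogen give lower numbers than the piperidin-1-yl compound. No measurement shown explains why the number rises when that nitrogen is lost.

The compounds shown leave open whether another atom in that ring position, such as the oxygen of morpholin-4-yl, would behave like the nitrogen or like the carbon. They also leave open how an open-chain amine or a smaller ring amine would read on the same aromatic carbon.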